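Biaryl propanamide series: replacing 3-methylphenyl by 2-fluorophenyl

The compounds below may be only part of what the source reports. "The series", "measured", "known", "first", "only" and "open" are said of these compounds alone.

Measured compounds:
- compound 1 `O=C(CCCCCCc1ccccc1)N1CCCC1`: 12900 nM
- compound 2 `Cc1ccccc1CCCCCCC(=O)N1CCCC1`: 68400 nM
- compound 3 `Cc1cccc(-c2ccc(CCC(=O)N3CCCC3)cc2)c1`: 16500 nM

Three compounds of the series have numbers in an assay on HEK293 cells for inhibition of N-acylethanolamine-hydrolyzing acid amidase (Rattus norvegicus), read by LC-MS, with a stated time of 30 min; a lower number here means a stronger inhibitor, a higher number a weaker inhibitor. Compound 1 gives 12900 nM in this assay. Going by the values given here, compound 2 gives 68400 nM in this assay, the step of a 5.3-fold higher number from compound 1 to compound 2 (0.72 log units; beyond the scatter) being the only single-point change with a measured pair. Compound 3 gives 16500 nM in this assay: second highest of the three numbers, with compound 1 the nearest and within the scatter of it, and compound 2 the furthest, beyond the scatter.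

Compound 4 `O=C(CCc1ccc(-c2ccccc2F)cc1)N1CCCC1` is not yet measured in this assay. It differs from compound 3 in one place: 2-fluorophenyl in place of 3-methylphenyl on an aromatic carbon. Among the compounds with values here, no measured pair changes a methyl for a fluorine, nor a 3-substituted for a 2-substituted phenyl; the step of a 5.3-fold higher number from compound 1 to compound 2 (0.72 log units; beyond the scatter) concerns a methyl on a different part of the core and bears on this change only loosely, as the one indication that a methyl on an aromatic carbon is not needed for the number seen. On that basis compound 4 is expected to stay close to compound 3, with the step of a 1.4-fold lower number from compound 3 to compound 4 (0.14 log units; within the scatter) estimated as no change beyond the scatter. The estimate for compound 4 in this assay is 12000 nM, with a range from 4000 nM to 40000 nM.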

Compound 4, half-maximal inhibitory concentration: 2800 nM
Compound 4: middle estimate off by 4.3-fold (0.63 log units), on the high side; measured number below the stated range.
By their numbers in this assay, from the lowest: compound 4; then compounds 1 and 3 (each within the scatter of the next); then compound 2.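

Within this assay, this position on the shared core proves sensitive to the aryl group it carries: the step of a 5.9-fold lower number from compound 3 to compound 4 (0.77 log units; beyond the scatter) is an exchange between two groups with the same heavy-atom count and no hydrogen-bond donors or acceptors. Going by these compounds alone, until now the only single-place change read beyond the scatter was a 5.3-fold higher number from compound 1 to compound 2 (0.72 log units; beyond the scatter), which concerned a methyl on a different core and went towards a higher number, so this is the first step to go towards a lower number. No measurement at hand accounts for the size or direction of the step.

The step changes the substituent and its place on the ring together, so it cannot show how much belongs to fluorine in place of methyl and how much to the change of place, and plain phenyl, a chlorine-bearing phenyl and a methoxy-bearing phenyl at this position would help to separate the two. From the compounds shown here alone, whether 2-fluorophenyl gives a similar step with a longer chain between the carbonyl and the core, or with piperidine in place of the pyrrolidine amide, also stays open.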